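Swapping the Aryl Group for Hydroxy: Compound 3 to Compound 4

The compounds below may be only part of what the source reports. "The series", "measured", "known", "first", "only" and "open" are said of these compounds alone.

Compound 1 `Cc1c(C(=O)N=C(N)N)cc(S(C)(=O)=O)c(Cl)c1C` gives 58 nM in a functional assay for inhibition of sodium/hydrogen exchanger (Oryctolagus cuniculus); on this read-out lower numbers stand for stronger inhibition and higher numbers for weaker inhibition.
Compound 2 `CCN(CC)Cc1cc(Br)c(S(C)(=O)=O)cc1C(=O)N=C(N)N` gives 9500 nM in this assay.
Compound 3 `Cc1cc(-c2ccc(F)cc2)c(S(C)(=O)=O)cc1C(=O)N=C(N)N` gives 36 nM in this assay.

Of these three numbers, compound 3 has the lowest. Compound 1 lies close enough to be within the scatter, so no order can be drawn between them, whereas compound 2 stands far higher, well beyond the scatter.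

Compound 4 `Cc1cc(O)c(S(C)(=O)=O)cc1C(=O)N=C(N)N` differs from compound 3 by hydroxy in place of 4-fluorophenyl on an aromatic carbon. For the measured compounds named here, no measured pair shows this change directly, so its effect is open. The compounds lacking the 4-fluorophenyl, compound 1 and compound 2, span a wide range, which leaves the direction uncertain. A moderate loss is expected in this assay, the step being estimated as an 8.3-fold higher number from compound 3 to compound 4 (0.92 log units; beyond the scatter). Compound 4 is estimated at 300 nM, with a range from 60 nM to 2000 nM.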

Compound 4, half-maximal inhibitory concentration: 220 nM
For compound 4 the middle estimate is 1.4-fold (0.13 log units) above the measured one; the range from low to high includes it.
By their numbers in this assay, from the lowest: compounds 3 and 1 (each within the scatter of the next); then compound 4; then compound 2.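

At the aromatic carbon ortho to a methylsulfonyl group, hydroxy in place of 4-fluorophenyl gives a 6.1-fold higher number from compound 3 to compound 4 (0.79 log units; beyond the scatter) in this assay, a modest loss of inhibition. The position therefore responds to what it carries, yet the aromatic ring of 4-fluorophenyl is not required for measurable inhibition. Nothing available explains this step.

As far as these compounds go, whether an amine or a methoxy group here would stand nearer compound 3 or compound 4 remains open. So does whether an unsubstituted phenyl would match 4-fluorophenyl.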